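The source may hold more compounds than are shown below. What is called first, only, known or untested is meant among the compounds shown, and "the series" means these compounds.

Of the compounds shown here, two sharing one core have been measured in a functional assay (aorta) for antagonist activity, with Oryctolagus cuniculus as the target; a higher number here means a weaker inhibitor, a lower number a stronger inhibitor. Compound 1 `CCCCc1ccc(CN(Cc2ccccc2)C(C)=O)c(=O)n1Cc1ccc(-c2ccccc2-c2nn[nH]n2)cc1` gives 1 nM in this assay, and compound 2 `CCCCc1ccc(CN(C)S(=O)(=O)c2ccc(C)cc2)c(=O)n1Cc1ccc(-c2ccccc2-c2nn[nH]n2)cc1` gives 8 nM. Going by the values given here, compound 2 thus stands with the higher of the two numbers, and the only measured step, an 8.0-fold higher number from compound 1 to compound 2 (0.90 log units; beyond the scatter), is what separates it from compound 1. Compound 3 `CCCCc1ccc(CN(Cc2ccccc2)S(=O)(=O)c2ccc(C)cc2)c(=O)n1Cc1ccc(-c2ccccc2-c2nn[nH]n2)cc1` differs from compound 2 by phenyl in place of hydrogen on a saturated chain carbon bound to a sulfonamide nitrogen. Among the compounds with values here, no measured step covers this change on its own. The step from compound 1 to compound 2 exchanged the whole acetyl(benzyl)amino group at once, so it bears on the present change only in part. Compound 1, which carries a benzyl in its acetyl(benzyl)amino group, gives 1 nM, the lower number. A moderate step back toward that number is expected, as a 2.7-fold lower number from compound 2 to compound 3 (0.43 log units; beyond the scatter). Compound 3 is estimated at 3 nM, within 1 nM to 15 nM.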

Compound 3, half-maximal inhibitory concentration: 60 nM
The estimate for compound 3 lay 20-fold (1.30 log units) below the measured number, outside the stated range (above it).
By their numbers in this assay, from the lowest: compound 1; then compound 2; then compound 3.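

In this assay, methyl to benzyl on the sulfonamide nitrogen gives a 7.5-fold higher number from compound 2 to compound 3 (0.88 log units; beyond the scatter), so with the (4-methylphenyl)sulfonyl group in place, benzyl goes with a higher number, not a lower one. Going by these compounds alone, with benzyl held fixed, (4-methylphenyl)sulfonyl in place of acetyl on the amine nitrogen gives a 60-fold higher number from compound 1 to compound 3 (1.78 log units; beyond the scatter), so benzyl alone does not carry the low number of compound 1, which is seen only with the acetyl group present. Nothing available here gives a reason for either step.

Going by these compounds, it remains open how methyl in place of benzyl would read on the acetyl amide, and so whether benzyl raises the number there too. Also open, on these data alone, is how an ethyl or a phenethyl on the sulfonamide nitrogen, or a methanesulfonyl in place of (4-methylphenyl)sulfonyl, would stand.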